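The compounds below may be only part of what the source reports. "The series", "measured", "known", "first", "only" and "open" are said of these compounds alone.

Measured so far in a functional assay (aorta) with Oryctolagus cuniculus as the target; a lower number here means tighter binding, a higher number weaker binding:
Compound 1 `COC(=O)c1ccc(OCCCN2CCC(C(c3ccc(F)cc3)c3ccc(F)cc3)CC2)c(OC)c1`: 1.26 nM
Compound 2 `NC(=O)c1ccc(OCCCN2CCC(C(c3ccc(F)cc3)c3ccc(F)cc3)CC2)cc1`: 31.6 nM
Compound 3 `Fc1ccc(C(c2ccc(F)cc2)C2CCN(CCCOc3ccc(Br)cc3)CC2)cc1`: 1.59 nM

Compound 3 shares the low end of this small set with compound 1. The gap between them is a 1.3-fold higher number from compound 1 to compound 3 (0.10 log units; within the scatter), so the two cannot be told apart. Compound 2 stands clearly apart, with a 20-fold lower number from compound 2 to compound 3 (1.30 log units; beyond the scatter).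

The next compound to be measured is compound 4 `CC(C)(C)c1ccc(OCCCN2CCC(C(c3ccc(F)cc3)c3ccc(F)cc3)CC2)cc1`, which keeps everything in compound 3 except one group. It carries tert-butyl in place of bromo on an aromatic carbon, para to a large group: tert-butyl in place of bromo on an aromatic carbon.

Among the measured compounds shown here, two measured steps bear on this change. The step of a 20-fold lower number from compound 2 to compound 3 (1.30 log units; beyond the scatter) alters the same aromatic carbon and shows that a swap there can matter a great deal. The step of a 1.3-fold higher number from compound 1 to compound 3 (0.10 log units; within the scatter) shows that a quite different substituted phenyl can leave the number unchanged. For the measured compounds named here, no measured compound carries tert-butyl, so neither step fixes the outcome directly. Going by the values given here, compound 2, the only compound with a high number, holds a carbamoyl group, and tert-butyl is not that group, so a large rise seems unlikely.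

The expected result is a 1.6-fold higher number from compound 3 to compound 4 (0.20 log units; within the scatter), which is a small change at most. For compound 4 the estimate is 2.5 nM, with an expected range from 0.8 nM to 8 nM.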

Compound 4, dissociation constant: 1 nM
Compound 4: middle estimate off by 2.5-fold (0.40 log units), on the high side; low and high end bracket the measured number.
By their numbers in this assay, from the lowest: compounds 4, 1 and 3 (each within the scatter of the next); then compound 2.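

In this assay, putting tert-butyl, with 4 heavy atoms, in place of bromo, with 1, on this aromatic carbon gives a 1.6-fold lower number from compound 3 to compound 4 (0.20 log units; within the scatter) and so stays within the scatter; the position therefore takes a clearly larger all-carbon group without a change that can be told from noise. The other two steps sharpen the picture: a 1.3-fold lower number from compound 1 to compound 4 (0.10 log units; within the scatter) also stays within the scatter, whereas a 32-fold lower number from compound 2 to compound 4 (1.50 log units; beyond the scatter) is large, which leaves the carbamoyl-bearing compound 2 as the only one of the four apart from the rest. No measurement shown here gives a reason for this difference.

As far as these compounds go, it remains open whether the high number is specific to carbamoyl, or whether a carboxylic acid, an amine or a hydroxyl on the same aromatic carbon would raise the number as well. From the compounds shown here alone, it is also open how much bulk this carbon can take, since a phenyl or a cyclohexyl group there could either match tert-butyl or mark the point where the number starts to climb.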